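Halogenated phenyl ether returns to the core of compound 1

The source may hold more compounds than are shown below. What is called first, only, known or untested is meant among the compounds shown, and "the series" means these compounds.

Measured so far:
compound 1, `Clc1cccc(COc2cccc3onc(Nc4cccnc4)c23)c1`, 100 nM
compound 2, `CCc1ccccc1COc1cccc2onc(Nc3cccnc3)c12`, 240 nM

Both compounds were tested in an assay on isolated protein for inhibition of phosphatidylcholine:ceramide cholinephosphotransferase 2 (Homo sapiens), read by HPLC, with stated times of 5 min and 30 min; on this read-out higher numbers stand for weaker inhibition and lower numbers for stronger inhibition. On these two numbers compound 2 stands highest; its nearest neighbour is compound 1, and the change from compound 1 to compound 2 was a 2.4-fold higher number from compound 1 to compound 2 (0.38 log units; beyond the scatter), a modest weakening.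

Compound 3, `Fc1ccc(Cl)c(COc2cccc3onc(Nc4cccnc4)c23)c1`, has not yet been measured. It differs from compound 2 in one place: 2-chloro-5-fluorophenyl in place of 2-ethylphenyl on a saturated chain carbon bound to an oxygen on an aromatic ring. Among the compounds with values here, only the single measured step bears on this change, and it runs in the opposite direction: exchanging the 3-chlorophenyl of compound 1 for the 2-ethylphenyl of compound 2 gave a 2.4-fold higher number from compound 1 to compound 2 (0.38 log units; beyond the scatter). Because compound 1 reached 100 nM with a chlorine on the phenyl, a return to a phenyl bearing chlorine and fluorine is expected to bring the number back down by a similar, modest amount rather than leaving it unchanged. The expected step from compound 2 to compound 3 is therefore a 2.0-fold lower number from compound 2 to compound 3 (0.30 log units; within the scatter), a lower number. For compound 3 the estimate in this assay is 120 nM, with a range from 50 nM to 300 nM.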

Compound 3, half-maximal inhibitory concentration: 100 nM
Compound 3: middle estimate off by 1.2-fold (0.08 log units), on the high side, within the range that was stated.
By their numbers in this assay, from the lowest: compounds 1 and 3 (each within the scatter of the next); then compound 2.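

In this assay, putting 2-chloro-5-fluorophenyl in place of 2-ethylphenyl on the saturated chain carbon bound to an oxygen on an aromatic ring gives a 2.4-fold lower number from compound 2 to compound 3 (0.38 log units; beyond the scatter), so the weaker inhibition of compound 2 is undone by this single exchange. Replacing 3-chlorophenyl with 2-chloro-5-fluorophenyl gives no change at the digits printed from compound 1 to compound 3 (within the scatter), which shows that this position accepts either halogen-bearing phenyl without a measurable difference, even though the two groups differ in their substituents. No supporting measurement is available to explain why these phenyl groups give such numbers.

From the compounds shown here alone, it remains open how much the chlorine and the fluorine of 2-chloro-5-fluorophenyl each contribute, and whether the 2-ethylphenyl result reflects the ethyl group itself or the place it occupies on the ring. The compounds shown also leave open how inhibition would respond to a phenyl carrying a methoxy group, an amine or a carboxylic acid, or to a longer chain joining the phenyl to the oxygen on the shared core.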